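This account rests on a few compounds, and the source may have more. Where it says the series, first, only, none or still open, it means among the compounds named here.

Working notes on the sulfonamide series. Two compounds have numbers in a functional assay on a cell-free system (plasma) for inhibition of thromboxane A2 receptor (Homo sapiens), read by turbidimetry; a lower number here means a stronger inhibitor, a higher number a weaker inhibitor. Compound 1 `Cc1ccc(S(=O)(=O)N[C@H]2CCC=C2C/C=C\CCC(=O)O)cc1` gives 1800 nM in this assay. Compound 2 `O=C(O)CC/C=C\CC1=CCC[C@@H]1NS(=O)(=O)c1ccc(F)cc1F` gives 20000 nM in this assay and so stands as the highest of the two numbers, its nearest neighbour being compound 1 with a lower figure. Among the measured compounds shown here, the one measured step, 2,4-difluorophenyl in place of 4-methylphenyl on the sulfonyl sulfur, reads an 11-fold higher number from compound 1 to compound 2 (1.05 log units; beyond the scatter), a large loss beyond the scatter.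

Compound 3 `O=C(O)CC/C=C\CC1=CCC[C@@H]1NS(=O)(=O)c1ccc(F)cc1` is not yet measured in this assay. It differs from compound 2 by hydrogen in place of fluoro on an aromatic carbon, on an aromatic carbon of a six-membered aromatic ring of carbon only, ortho to a large group and meta to a fluoro group; cut one bond further out the change reads 2,4-difluorophenyl to 4-fluorophenyl. For the measured compounds named here, the only step that bears on it is an 11-fold higher number from compound 1 to compound 2 (1.05 log units; beyond the scatter), which brought both fluoro groups in at once; no step separates the two. Removing one of them is expected to recover part of that loss, so a moderate step toward a lower number, a 3.3-fold lower number from compound 2 to compound 3 (0.52 log units; beyond the scatter), is expected. Compound 3 is thus estimated at 6000 nM in this assay, within 2000 nM to 18000 nM.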

Compound 3, half-maximal inhibitory concentration: 1300 nM
For compound 3 the middle estimate is 4.6-fold (0.66 log units) above the measured one; the whole stated range lies above it.
By their numbers in this assay, from the lowest: compounds 3 and 1 (each within the scatter of the next); then compound 2.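

In this assay, removing only the fluoro ortho to a large group gives a 15-fold lower number from compound 2 to compound 3 (1.19 log units; beyond the scatter) and so takes back the whole of the earlier loss, which the paired change of compound 2 could not assign to either fluoro group. The second comparison gives a 1.4-fold lower number from compound 1 to compound 3 (0.14 log units; within the scatter), so 4-fluorophenyl and 4-methylphenyl cannot be told apart here, and among these three compounds the large shift goes with the added fluoro at the carbon ortho to a large group and meta to a fluoro group. Nothing at hand explains why a single fluoro at this carbon has a step of this size.

From the compounds shown here alone, it remains open whether chloro, methyl or methoxy at this same carbon would give a similar step, and whether that step would hold with a 4-methylphenyl group in place of 4-fluorophenyl. Also open, going by these compounds, is how unsubstituted phenyl, or a 4-trifluoromethylphenyl group, would compare with compound 3 on the shared core.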